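The source may report more compounds than this note shows. Statements on the series, on what has been measured and on what is new or still open speak of the compounds shown alone.

Measured so far:
compound 1, `COc1ccc(-c2cc(/C=C/C(=O)c3ccc(N)cc3)[nH]n2)cc1`: 98%
compound 2, `COc1cc(-c2cc(/C=C/C(=O)c3ccc(N)cc3)[nH]n2)cc(OC)c1OC`: 94%

In a functional assay on A549 cells (Homo sapiens) for cytotoxicity, read by sulforhodamine B assay, with a stated time of 48 h, tested at 0.1 uM (on this read-out lower numbers stand for a stronger effect and higher numbers for a weaker effect at the one concentration tested), compound 2 holds the lowest of the two numbers; its nearest neighbour, compound 1, lies within the scatter of it, so the two are not separated on this read-out. Going by the values given here, no step between measured compounds is available to lean on.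

Compound 3, `COc1ccc(-c2cc(/C=C/C(=O)c3ccc(N)cc3)[nH]n2)cc1OC`, differs from compound 2 by hydrogen in place of methoxy on an aromatic carbon. With both measured numbers lying close together, the expected step is a number 2 percentage points higher from compound 2 to compound 3 (within the scatter), nothing beyond the scatter in either direction. Compound 3 is therefore estimated at 96%, within a range of 86% to 103%.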

Compound 3, a percentage reported as activity, at one concentration (the size of the read-out at that concentration, not a potency): 93%
Estimate against measurement, compound 3: 3 percentage points above, and the stated range covers the measured number.
By their numbers in this assay, from the lowest: compounds 3, 2 and 1 (each within the scatter of the next).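

In this assay hydrogen in place of methoxy on an aromatic carbon gives a number 1 percentage points lower from compound 2 to compound 3 (within the scatter) and methoxy in place of hydrogen on an aromatic carbon gives a number 5 percentage points lower from compound 1 to compound 3 (within the scatter) in the same ring. Going by these compounds alone, these are the first single-place changes, and neither separates the compounds on this read-out at the one concentration tested. Nothing at hand bears on a reason for this result.

On these data alone, whether an amine, a hydroxyl group or a fluorine atom in place of methoxy on this aromatic carbon would give a step beyond the scatter stays open. So does any ranking of these three compounds at a higher concentration.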